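Nitro to methoxy: what one measured step suggests

The source may report more compounds than this note shows. Statements on the series, on what has been measured and on what is new or still open speak of the compounds shown alone.

In a functional assay (Homo sapiens) for inhibition (on this read-out higher numbers stand for weaker inhibition and lower numbers for stronger inhibition), compound 1 `CCCCCCc1cc(/C=C/C(=O)c2ccc(O)cc2)c(OC)cc1O` gives 46000 nM and compound 2 `CCCCOc1cccc(C(=O)/C=C/c2ccc(OC)cc2OC)c1` gives 65000 nM. Compound 3 `COc1ccc(/C=C/C(=O)c2cccc([N+](=O)[O-])c2)c(OC)c1` gives 18000 nM, the lowest number of the three and clearly apart from both others. Compound 4 `COc1cccc(C(=O)/C=C/c2ccc(OC)cc2OC)c1` has not yet been measured. It follows from compound 3 by methoxy in place of nitro on an aromatic carbon, meta to a large group (methoxy in place of nitro on an aromatic carbon).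

Among the measured compounds shown here, only one measured step bears on this change. That step is a 3.6-fold lower number from compound 2 to compound 3 (0.56 log units; beyond the scatter), in which nitro took the place of butoxy on an aromatic carbon. The change now in view also involves nitro at an aromatic carbon, but nitro leaves instead of entering, so the number is expected to move upward. Methoxy is not butoxy, and no measurement yet shows how far the smaller group would carry the number, so a somewhat smaller step than that one is expected. The expected step is a 2.2-fold higher number from compound 3 to compound 4 (0.35 log units; beyond the scatter). For compound 4 the estimated value is 40000 nM, with an expected range from 15000 nM to 90000 nM.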

Compound 4, half-maximal inhibitory concentration: 42000 nM
Beside the measured number, compound 4's estimate is 1.1-fold (0.02 log units) below it, and the stated range covers the measured number.
By their numbers in this assay, from the lowest: compound 3; then compounds 4, 1 and 2 (each within the scatter of the next).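

In this assay, the move of a 2.3-fold higher number from compound 3 to compound 4 (0.37 log units; beyond the scatter) shows that on this aromatic carbon, meta to a large group, methoxy does not stand in for nitro: the replacement is felt beyond the scatter, and the compound carrying nitro keeps the lowest number. Among the compounds shown here, the second comparison adds what the earlier compounds could not show, namely that shortening the ether chain on this same carbon, with a 1.5-fold lower number from compound 2 to compound 4 (0.19 log units; within the scatter) as hydrogen replaces propyl, gives no difference that can be told from the scatter, so butoxy and methoxy stand together here while nitro stands apart from both. Nothing measured here accounts for the gap between nitro and the two ether groups.

On these data alone, what remains open is whether this separation belongs to nitro alone, since a single nitro compound carries the whole contrast, and an amine or a carboxylic acid on this carbon could fall on either side of it. As far as these compounds go, it is also open whether a chain longer than butoxy would stay level with the two ethers or move the number away from them.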